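Bromo for Chloro Where Both Neighbours Sit at the Limit

This account rests on a few compounds, and the source may have more. Where it says the series, first, only, none or still open, it means among the compounds named here.

Two measured compounds share one core. Compound 1 `Fc1cccc(-c2nc(Nc3cccc(Cl)c3)c3cc(F)ccc3n2)c1` carries a 3-chlorophenyl group on a nitrogen on an aromatic ring. In a functional assay on HT29-AK cells (Homo sapiens) for cytotoxicity, read by MTT assay, with a stated time of 48 h (on this read-out higher numbers stand for weaker inhibition and lower numbers for stronger inhibition), compound 1 gives only a limit, > 50000 nM. Compound 2 `Fc1cccc(-c2nc(Nc3ccccc3Cl)c3cc(F)ccc3n2)c1` carries a 2-chlorophenyl group in place of the 3-chlorophenyl on that nitrogen. In this assay compound 2 likewise gives only a limit, > 50000 nM. The step that the two limits leave unreadable from compound 1 to compound 2 cannot be read because of the limit of > 50000 nM in this assay, at which 2 of the 2 values shown sit. Within the data shown here, compound 2 therefore stands at the limit, as does the one other value shown.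

Compound 3 `Fc1cccc(-c2nc(Nc3ccccc3Br)c3cc(F)ccc3n2)c1` differs from compound 2 by bromo in place of chloro on an aromatic carbon; in words, bromo replaces chloro on an aromatic carbon of a six-membered aromatic ring of carbon only, ortho to a large group. Among the measured compounds shown here, only the single measured step bears on this change, and its size is not readable. For the measured compounds named here, no measured step shows a direction in this assay, so compound 3 is expected to sit at or near the limit as well. Compound 3 is estimated at 60000 nM, with a range from 20000 nM to 200000 nM, which means an expected step that the limit leaves unreadable from compound 2 to compound 3.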

Compound 3, half-maximal inhibitory concentration: > 50000 nM
Compound 3: no number, only a limit (the forecaster's own chance of this, stated with the estimate: 85%); the middle value lies beyond the limit too.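

In this assay compound 3 gives only a limit (> 50000 nM). Among these compounds, no step from compound 1 or compound 2 to compound 3 can be read: (the limit of > 50000 nM in this assay, at which 3 of the 3 values shown sit). The compounds shown leave open whether bromo in place of chloro, or 2-chlorophenyl in place of 3-chlorophenyl, changes the cytotoxicity of the shared core at all in this assay at any readable value.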